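This account rests on a few compounds, and the source may have more. Where it says the series, first, only, none or still open, it means among the compounds named here.

Measured so far:
compound 1 `CCn1c(C(=O)N[C@@H](C)C(=O)OC)ccc1C(CC)(CC)c1ccc(OCS(=O)(=O)c2ccccc2)c(C)c1`: 17900 nM
compound 2 `CCn1c(C(=O)N[C@H](C)C(=O)OC)ccc1C(CC)(CC)c1ccc(OCS(=O)(=O)c2ccccc2)c(C)c1`: limit only, > 50000 nM
compound 3 `CCn1c(C(=O)NC(C)(C)CO)ccc1C(CC)(CC)c1ccc(OCS(=O)(=O)c2ccccc2)c(C)c1`: 18300 nM

In a functional assay on BXPC-3 cells (Homo sapiens) for antiproliferative activity, read by MTT assay, with a stated time of 24 h (on this read-out lower numbers stand for stronger inhibition and higher numbers for weaker inhibition), compound 1 gives 17900 nM and compound 3 gives 18300 nM; the two sit within the scatter of each other, a 1.0-fold higher number from compound 1 to compound 3 (0.01 log units; within the scatter). Compound 2 returns only a limit, > 50000 nM, which is the limit of > 50000 nM in this assay, at which 1 of the 3 values shown sits. Compound 2 therefore stands at the weak end of the numbers in hand: an at least 2.7-fold higher number from compound 1 to compound 2 (0.44 log units; beyond the scatter), a step that rests on (the fact that compounds 1 and 2 differ only in the configuration as drawn).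

Compound 4 `CCn1c(C(=O)N[C@@H](CO)C(C)C)ccc1C(CC)(CC)c1ccc(OCS(=O)(=O)c2ccccc2)c(C)c1` is not yet measured. Against compound 2 the change is 1-(hydroxymethyl)-2-methylpropyl in place of 1-(methoxycarbonyl)ethyl on an amide-type nitrogen. Among the measured compounds shown here, two measured steps bear on it. The closer one is an at least 2.7-fold lower number from compound 2 to compound 3 (0.43 log units; beyond the scatter), where a hydroxymethyl-bearing substituent likewise replaces the 1-(methoxycarbonyl)ethyl on the amide-type nitrogen and the number returns to the region of compound 1. The other is an at least 2.7-fold higher number from compound 1 to compound 2 (0.44 log units; beyond the scatter), which shows that the configuration at the chain carbon alone can push the number past the limit. Compound 4 has a defined stereocentre of its own, and the steps in hand do not settle how that will weigh.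

A downward step from the limit is expected, an at least 2.5-fold lower number from compound 2 to compound 4 (0.39 log units; beyond the scatter). Compound 4 is expected to give 20000 nM, with a range of 8000 nM to 50000 nM.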

Compound 4, half-maximal inhibitory concentration: 13200 nM
The estimate for compound 4 lay 1.5-fold (0.18 log units) above the measured number; the range from low to high includes it.
By their numbers in this assay, from the lowest: compounds 4, 1 and 3 (each within the scatter of the next). At a limit, above all of these: compound 2.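

At the amide-type nitrogen, 1-(hydroxymethyl)-2-methylpropyl is a second hydroxymethyl-bearing substituent that brings the number down from the limit (an at least 3.7-fold lower number from compound 2 to compound 4 (0.57 log units; beyond the scatter)). This step gives only a bound on its size, because its starting point is a limit and not a number: (the limit of > 50000 nM in this assay, at which 1 of the 4 values shown sits). The result also adds a hydroxymethyl-bearing substituent with a defined stereocentre to the picture at this position, and in this assay it cannot be separated from either the 1-(hydroxymethyl)-1-methylethyl group (a 1.4-fold lower number from compound 3 to compound 4 (0.14 log units; within the scatter)) or the other configuration of 1-(methoxycarbonyl)ethyl (a 1.4-fold lower number from compound 1 to compound 4 (0.13 log units; within the scatter)).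

Going by these compounds, it remains open whether the opposite configuration of 1-(hydroxymethyl)-2-methylpropyl would shift the number as configuration did for the 1-(methoxycarbonyl)ethyl pair (an at least 2.7-fold higher number from compound 1 to compound 2 (0.44 log units; beyond the scatter)). Also open, on these data alone, is what a carboxylic acid, a primary amine or a longer chain carrying the hydroxyl would give on this amide-type nitrogen, and whether any such group would separate from the cluster of values now in hand.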